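A Methyl Added to a Hydroxyethyl Chain

The compounds below may be only part of what the source reports. "The series", "measured", "known", "first", "only" and "open" are said of these compounds alone.

Measured so far:
Compound 1, `CCn1cnc2ncnc(N)c21`: > 30000 nM, a limit of the assay.
Compound 2, `CCCn1cnc2ncnc(N)c21`: > 30000 nM, a limit of the assay.
Compound 3, `Nc1ncnc2ncn(CCO)c12`: > 30000 nM, a limit of the assay.

The three compounds share one core and differ only in the short chain on the ring nitrogen. In a functional assay on CHO cells for antagonist activity at adenosine receptor A2b (Homo sapiens) (on this read-out higher numbers stand for weaker inhibition and lower numbers for stronger inhibition), none of them yields a real number: each sits at the limit of > 30000 nM in this assay, at which 3 of the 3 values shown sit. Compound 3, with its hydroxyethyl chain, therefore stands at the same limit as the others, and how it compares with them cannot be told. The steps a step that the two limits leave unreadable from compound 1 to compound 2, a step that the two limits leave unreadable from compound 1 to compound 3 and a step that the two limits leave unreadable from compound 2 to compound 3 are all unreadable for the same reason, so no measured step gives a direction to build on.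

Compound 4, `CC(O)Cn1cnc2ncnc(N)c21`, carries the change (methyl in place of hydrogen on a saturated chain carbon bound to an oxygen on a saturated carbon and a saturated chain carbon). Among the measured compounds shown here, the only related steps, those among compounds 1, 2 and 3, are unreadable, so compound 4 is expected to stay at the limit in this assay, with an expected step that the limit leaves unreadable from compound 3 to compound 4 of no readable size. The estimate for compound 4 is 40000 nM, in an expected range from 15000 nM to 120000 nM.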

Compound 4, inhibition constant: > 30000 nM
Compound 4: a limit, no number; the forecaster's own chance of this, stated with the estimate: 90%; the middle value is on the limit's open side.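

Compound 4 also gives only a limit of the assay, not a number, so its steps from compound 1, compound 2 and compound 3 cannot be read: the limit of > 30000 nM in this assay, at which 4 of the 4 values shown sit.

The compounds shown leave open whether any short chain on this core gives a real number in this assay and how far the four compounds truly differ.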